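The source may report more compounds than this note shows. Statements on the series, on what has been measured and on what is new or still open speak of the compounds shown alone.

Three amides on the shared core of compound 1 `CC(C)=CC(=O)Nc1c(C(O)(C(F)(F)F)C(F)(F)F)ccc2ccccc12` have been measured in an assay on LtK cells with ATP-sensitive inward rectifier potassium channel 11 (Homo sapiens) as the target; a lower number here means that less compound is needed, a higher number that more compound is needed for the effect. Compound 1 gives 46 nM, compound 2 `C/C=C/C(=O)Nc1c(C(O)(C(F)(F)F)C(F)(F)F)ccc2ccccc12` gives 72 nM, and compound 3 `O=C(Nc1c(C(O)(C(F)(F)F)C(F)(F)F)ccc2ccccc12)c1ccccc1` gives 44 nM. The three differ only in the group on the carbonyl carbon, and every step among them stays within the scatter: a 1.6-fold higher number from compound 1 to compound 2 (0.19 log units; within the scatter), a 1.0-fold lower number from compound 1 to compound 3 (0.02 log units; within the scatter), a 1.6-fold lower number from compound 2 to compound 3 (0.21 log units; within the scatter). Compound 3 shows the lowest of the three numbers, but its gaps to compound 1 and compound 2 both lie within the scatter. Compound 4 `O=C(Nc1c(C(O)(C(F)(F)F)C(F)(F)F)ccc2ccccc12)c1cccc(C(F)(F)F)c1` keeps the phenyl of compound 3 and carries trifluoromethyl in place of hydrogen on an aromatic carbon. Going by the values given here, no measured step touches a substituent on the phenyl; the known steps swap the whole group on the carbonyl carbon and none leaves the scatter. Among the compounds with values here, with no bearing step, the expectation is a 1.1-fold lower number from compound 3 to compound 4 (0.04 log units; within the scatter), nothing beyond the scatter. Compound 4 is therefore estimated at 40 nM, within 12 nM to 130 nM.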

Compound 4, half-maximal effective concentration: 84 nM
For compound 4 the middle estimate is 2.1-fold (0.32 log units) below the measured one; measured number inside the range.
By their numbers in this assay, from the lowest: compounds 3, 1, 2 and 4 (each within the scatter of the next).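

Trifluoromethyl on the phenyl of compound 3 is the first change on that ring in the series, and it stays within the scatter (a 1.9-fold higher number from compound 3 to compound 4 (0.28 log units; within the scatter)) in this assay. Exchanging the whole group on the carbonyl carbon for 3-(trifluoromethyl)phenyl also stays within it (a 1.2-fold higher number from compound 2 to compound 4 (0.07 log units; within the scatter); a 1.8-fold higher number from compound 1 to compound 4 (0.26 log units; within the scatter)). No evidence bears on this result.

From the compounds shown here alone, whether other positions on the phenyl tolerate trifluoromethyl equally remains open. So does the outcome with a different substituent on that ring, such as an amine, a nitrile or a carboxylic acid.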